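A New Aryl Group on the Aromatic Nitrogen

This account rests on a few compounds, and the source may have more. Where it says the series, first, only, none or still open, it means among the compounds named here.

In a functional assay on MCF7 cells (Homo sapiens) for cytotoxicity, read by MTT assay, with a stated time of 96 h (a lower number here means a stronger inhibitor, a higher number a weaker inhibitor), compound 1 `COc1cc(C(=O)c2cn(-c3ccccc3[N+](=O)[O-])cc2-c2ccccc2)cc(OC)c1OC` gives 5000 nM, while compound 2 `COc1cc(C(=O)c2cn(-c3cccc(Br)c3)cc2-c2ccccc2)cc(OC)c1OC` gives 78 nM, the lower of the two numbers. Compound 3 `COc1cc(C(=O)c2cn(-c3ccc(N)cc3)cc2-c2ccccc2)cc(OC)c1OC` awaits measurement. It carries 4-aminophenyl in place of 3-bromophenyl on an aromatic nitrogen. For the measured compounds named here, only one measured step bears on this change, and it concerns the same place: a 64-fold lower number from compound 1 to compound 2 (1.81 log units; beyond the scatter), with 3-bromophenyl in place of 2-nitrophenyl. That large step shows that swapping the group on this nitrogen can move the number substantially. Yet neither measured compound carries 4-aminophenyl, so the step sets no direction for the new change. The best guess is therefore no shift beyond the scatter, with wide margins on either side. The expected change is a 1.3-fold lower number from compound 2 to compound 3 (0.11 log units; within the scatter). Compound 3 is estimated at 60 nM, with an expected range of 12 nM to 400 nM.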

Compound 3, half-maximal inhibitory concentration: 35 nM
Compound 3: middle estimate off by 1.7-fold (0.23 log units), on the high side; low and high end bracket the measured number.
By their numbers in this assay, from the lowest: compound 3; then compound 2; then compound 1.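

In this assay on this nitrogen, 4-aminophenyl brings a 2.2-fold lower number from compound 2 to compound 3 (0.35 log units; beyond the scatter) as a modest step and a 140-fold lower number from compound 1 to compound 3 (2.15 log units; beyond the scatter) as a large one, which puts compound 3 lowest of the three. The 4-aminophenyl has the same 7 heavy atoms as the 3-bromophenyl it replaces, but it has 1 hydrogen-bond donor and 1 hydrogen-bond acceptor where that group has none, so this position accepts such a group without the number rising. Nothing at hand explains either step.

The amine and the bromine also sit at different places on their rings, so the compounds shown do not separate the identity of the group from its place. From the compounds shown here alone, it remains open how 3-aminophenyl, 4-bromophenyl or a phenyl ring bearing a carboxylic acid would compare on this nitrogen.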